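The source may hold more compounds than are shown below. What is called first, only, known or untested is meant among the compounds shown, and "the series" means these compounds.

Compound 2 `CSc1cc(C)nc(Cl)c1NC(=O)N(Cc1ccc(Oc2ccc(F)cc2)cc1)C1CCCCCC1` gives 46 nM in an assay for inhibition of acyl-CoA:cholesterol acyltransferase (Oryctolagus cuniculus), using microsomes (on this read-out higher numbers stand for weaker inhibition and lower numbers for stronger inhibition), the lower of the two numbers recorded so far, although the step of a 1.2-fold lower number from compound 1 to compound 2 (0.09 log units; within the scatter) shows that compound 1 `CSc1nc(C)nc(SC)c1NC(=O)N(Cc1ccc(Oc2ccc(F)cc2)cc1)C1CCCCCC1`, which gives 56 nM, is not distinguishable from it. Compound 3 `Cc1cc(S(C)(=O)=O)c(NC(=O)N(Cc2ccc(Oc3ccc(F)cc3)cc2)C2CCCCCC2)c(Cl)n1` differs from compound 2 by methylsulfonyl in place of methylsulfanyl on an aromatic carbon. Within the data shown here, no measured step addresses this kind of change; the one available step, a 1.2-fold lower number from compound 1 to compound 2 (0.09 log units; within the scatter), altered a different part of the core and stayed within scatter. The expected step from compound 2 to compound 3 in this assay is therefore a 1.5-fold higher number from compound 2 to compound 3 (0.18 log units; within the scatter), none beyond scatter. Compound 3 is estimated at 70 nM, with a range from 25 nM to 200 nM.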

Compound 3, half-maximal inhibitory concentration: 30 nM
The estimate for compound 3 lay 2.3-fold (0.37 log units) above the measured number; the range from low to high includes it.
By their numbers in this assay, from the lowest: compounds 3, 2 and 1 (each within the scatter of the next).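

At this carbon opposite the ring nitrogen, methylsulfonyl can take the place of methylsulfanyl in this assay with a step of a 1.5-fold lower number from compound 2 to compound 3 (0.19 log units; within the scatter), so the larger group with two added oxygens stays level with the smaller one. The step of a 1.9-fold lower number from compound 1 to compound 3 (0.27 log units; within the scatter), which changes the ring and its groups together, also leaves the compounds level. Nothing measured here bears on the reason for this result. Going by these compounds, whether an amine, a carboxylic acid or a longer chain at this carbon would stay within the scatter remains open.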